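Adding a methyl to the acid side chain of compound 2

The compounds below may be only part of what the source reports. "The series", "measured", "known", "first", "only" and "open" are said of these compounds alone.

Clearance values from an ADME assay on cells (Hepatocyte, Mus musculus) for metabolic stability, read by LC-MS, with a stated time of 180 min, tested at 1 uM (on this read-out lower numbers stand for slow clearance and higher numbers for fast clearance), are as follows:
- Compound 1 `O=C(O)Cn1nc(Cc2nc3cc(Cl)c(OC(F)(F)F)cc3[nH]2)c2ccccc2c1=O` gives < 38.4 mL/min/kg which is a limit and not a number
- Compound 2 `O=C(O)Cc1nn(Cc2cn3cc(OCC4CC4)c(Cl)cc3n2)c2ccccc2c1=O` gives 30 mL/min/kg
- Compound 3 `CC(C(=O)O)c1nn(Cc2cn3cc(OCC4CC4)c(C(F)(F)F)cc3n2)c2ccccc2c1=O` gives 71.7 mL/min/kg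

Of the two exact numbers, compound 2 has the lower, and the gap up to compound 3 lies beyond the usual scatter. Compound 4 `C[C@H](C(=O)O)c1nn(Cc2cn3cc(OCC4CC4)c(Cl)cc3n2)c2ccccc2c1=O` differs from compound 2 in one place, where carboxymethyl becomes 1-carboxyethyl (methyl in place of hydrogen on a saturated chain carbon bound to an aromatic carbon and a carbonyl carbon). Among the measured compounds shown here, no measured pair shows this change alone. Compound 3 also carries 1-carboxyethyl and gives 71.7 mL/min/kg but differs from compound 2 elsewhere too, so it is only a weak guide. A small rise in this assay is expected, and the estimated step of a 1.4-fold higher number from compound 2 to compound 4 (0.15 log units; within the scatter) stays within the scatter. The estimate for compound 4 is 42 mL/min/kg (expected range 22 mL/min/kg to 80 mL/min/kg).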

Compound 4, clearance in the Hepatocyte assay: 33.3 mL/min/kg
Compound 4: the middle estimate sits 1.3-fold (0.10 log units) above what was measured, within the range that was stated.
By their numbers in the Hepatocyte assay, from the lowest: compounds 2 and 4 (each within the scatter of the next); then compound 3.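

In the Hepatocyte assay compound 2 gives 30 mL/min/kg and compound 4 gives 33.3 mL/min/kg. Among the compounds shown here, in the Hepatocyte assay, methyl in place of hydrogen on this saturated chain carbon gives a 1.1-fold higher number from compound 2 to compound 4 (0.05 log units; within the scatter), so this position takes the extra carbon with no readable change, something no earlier pair could show. In a physicochemical assay for solubility, measured as thermodynamic solubility, at pH 7.4 (on this read-out higher numbers stand for higher solubility and lower numbers for lower solubility), compound 2 gives 919 ug/mL and compound 4 gives 892 ug/mL. In the physicochemical assay, the same change gives a 1.0-fold lower number from compound 2 to compound 4 (0.01 log units; within the scatter), so neither read-out separates the two compounds. Nothing measured here offers an explanation for this result.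

Still open, going by these compounds, is whether a longer chain such as ethyl, or a hydroxyl group, on this carbon would leave both read-outs just as unmoved.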